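Exchange of the ring amine substituent: compound 3 to compound 4

This account rests on a few compounds, and the source may have more. Where it says the series, first, only, none or still open, it means among the compounds named here.

Measured so far:
compound 1 `COc1cc[nH]c1/C=C1\C(=O)Nc2ccc([N+](=O)[O-])c(N3CC[C@H](O)C3)c21`: 37 nM
compound 2 `COc1cc[nH]c1/C=C1\C(=O)Nc2ccc([N+](=O)[O-])cc21`: 692 nM
compound 3 `COc1cc[nH]c1/C=C1\C(=O)Nc2ccc([N+](=O)[O-])c(N3CC[C@@H](O)C3)c21`: 32 nM

In a functional assay on RKO cells (Homo sapiens) for antiproliferative activity, read by MTT assay, with a stated time of 5 days (on this read-out higher numbers stand for weaker inhibition and lower numbers for stronger inhibition), compound 3 gives the lowest number of the three. The step of a 1.2-fold lower number from compound 1 to compound 3 (0.06 log units; within the scatter) lies within the scatter, and the two compounds differ only in configuration as drawn (the fact that compounds 1 and 3 differ only in the configuration as drawn), so compound 1 and compound 3 are read as equivalent. The step of a 22-fold lower number from compound 2 to compound 3 (1.33 log units; beyond the scatter) is the large one in the set: removing the ring amine at this carbon costs most of the activity.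

Compound 4 `COc1cc[nH]c1/C=C1\C(=O)Nc2ccc([N+](=O)[O-])c(N3CCC(N)CC3)c21` is not yet measured. The change from compound 3 is 4-aminopiperidin-1-yl in place of 3-hydroxypyrrolidin-1-yl on an aromatic carbon. For the measured compounds named here, two measured steps bear on it. The presence of a saturated amine ring at this position matters greatly, as a 22-fold lower number from compound 2 to compound 3 (1.33 log units; beyond the scatter) shows, while the arrangement within that ring matters little, as a 1.2-fold lower number from compound 1 to compound 3 (0.06 log units; within the scatter) shows. Compound 4 keeps a saturated amine ring at the same carbon, with the same count of hydrogen-bond donors and acceptors, so a number near that of compound 3 is expected, with the step of a 1.3-fold higher number from compound 3 to compound 4 (0.10 log units; within the scatter) not expected to go beyond the scatter in either direction. The estimate for compound 4 is 40 nM, with a range from 15 nM to 130 nM.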

Compound 4, half-maximal inhibitory concentration: < 10 nM
Compound 4 gave a limit, no number (the forecaster's own chance of this, stated with the estimate: 0%); middle value at least 4.0-fold (0.60 log units) from the limit.
By their numbers in this assay, from the lowest: compounds 3 and 1 (each within the scatter of the next); then compound 2. At a limit, below all of these: compound 4.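

In this assay compound 4 gives < 10 nM, which is a limit of the assay and not a number. At this aromatic carbon, ortho to the nitro group, the identity of the saturated amine ring matters after all: an at least 3.2-fold lower number from compound 3 to compound 4 (0.50 log units; beyond the scatter) and an at least 3.7-fold lower number from compound 1 to compound 4 (0.56 log units; beyond the scatter), both beyond the scatter, whereas the change of configuration within 3-hydroxypyrrolidin-1-yl stays within it. Measured against hydrogen at the same carbon, the replacement gives an at least 69-fold lower number from compound 2 to compound 4 (1.84 log units; beyond the scatter), and this step and the other two are bounded on one side only: the limit of < 10 nM in this assay, at which 1 of the 4 values shown sits.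

The change from 3-hydroxypyrrolidin-1-yl to 4-aminopiperidin-1-yl alters the ring size and exchanges the hydroxyl for an amine in one step, so the compounds shown do not tell which of the two carries the gain. Either 4-hydroxypiperidin-1-yl or 3-aminopyrrolidin-1-yl at this carbon would separate the two, and how far below the limit compound 4 lies remains unknown.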